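Swapping the hydrazone aryl group on a shared triazine core

This account rests on a few compounds, and the source may have more. Where it says the series, first, only, none or still open, it means among the compounds named here.

Measured so far:
compound 1 `NS(=O)(=O)c1ccc(Nc2nc(N/N=C/c3ccc(C(F)(F)F)cc3)nc(Nc3ccccc3)n2)cc1` with 3060 nM
compound 2 `Cc1nn(-c2ccccc2)cc1/C=N/Nc1nc(Nc2ccccc2)nc(Nc2ccc(S(N)(=O)=O)cc2)n1` with 2290 nM

In a functional assay on MOLT-4 cells (Homo sapiens) for inhibition, read by sulforhodamine B assay, with a stated time of 48 h (on this read-out higher numbers stand for weaker inhibition of growth and lower numbers for stronger inhibition of growth), compound 2 gives 2290 nM and compound 1 gives 3060 nM; these two numbers lie within the scatter of each other, so neither can be called stronger.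

Compound 3 `NS(=O)(=O)c1ccc(Nc2nc(N/N=C/c3ccccn3)nc(Nc3ccccc3)n2)cc1` has not been measured. It differs from compound 2 in one place: pyridin-2-yl in place of 3-methyl-1-phenyl-1H-pyrazol-4-yl on a carbon with a double bond to nitrogen.

Among the measured compounds shown here, only one measured step bears on this change, the exchange of the same aryl group between compound 1 and compound 2, which gave a 1.3-fold lower number from compound 1 to compound 2 (0.13 log units; within the scatter). That exchange of one aromatic group for another at this position left the number essentially unchanged. On that basis, compound 3 is expected to show a step of a 1.1-fold higher number from compound 2 to compound 3 (0.04 log units; within the scatter), that is, no change beyond the scatter in this assay.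

For compound 3 the estimate in this assay is therefore 2500 nM, with a range from 900 nM to 7000 nM.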

Compound 3, concentration for 50% growth inhibition: 430 nM
Estimate against measurement, compound 3: 5.8-fold (0.76 log units) above; the whole stated range lies above it.
By their numbers in this assay, from the lowest: compound 3; then compounds 2 and 1 (each within the scatter of the next).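

In this assay, the group on the carbon with a double bond to nitrogen now clearly matters: the earlier exchange of aromatic groups stayed within the scatter, but pyridin-2-yl gives a 5.3-fold lower number from compound 2 to compound 3 (0.73 log units; beyond the scatter) and a 7.1-fold lower number from compound 1 to compound 3 (0.85 log units; beyond the scatter). So these aromatic groups are not interchangeable at this place, and compound 3 has the lowest number of the three, with both steps to it beyond the scatter. Nothing measured here explains this difference.

Compared with 3-methyl-1-phenyl-1H-pyrazol-4-yl, pyridin-2-yl has fewer heavy atoms and a different ring make-up, so this single change cannot show which feature counts. An unsubstituted phenyl group on the same carbon would help separate the effect of the ring nitrogen from that of size.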